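The compounds below may be only part of what the source reports. "The series", "measured", "known", "first", "only" and "open" are said of these compounds alone.

Measured in a functional assay on A549 cells (Homo sapiens) for antiproliferative activity, read by MTT assay, with a stated time of 72 h (a higher number here means a weaker inhibitor of growth, a lower number a stronger inhibitor of growth), each value a limit:
compound 1 `Cc1ccc(-n2nnc(C(=O)Nc3ccc(SC#N)cc3)c2C)cc1C`: > 100000 nM
compound 2 `Cc1ccc(Cl)cc1-n1nnc(C(=O)Nc2ccc(SC#N)cc2)c1C`: > 100000 nM
compound 3 `Cc1ccc(Cl)c(-n2nnc(C(=O)Nc3ccc(SC#N)cc3)c2C)c1`: > 100000 nM

Compound 3 has no number, only a limit. It stands with the other two compounds at the limit of > 100000 nM in this assay, at which 3 of the 3 values shown sit.

The step of interest leads to compound 4 `COc1cccc(-n2nnc(C(=O)Nc3ccc(SC#N)cc3)c2C)c1`, with 3-methoxyphenyl in place of 2-chloro-5-methylphenyl on an aromatic nitrogen.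

The measured steps that bear on this one change the group on the same aromatic nitrogen. They are a step that the two limits leave unreadable from compound 1 to compound 3, a step that the two limits leave unreadable from compound 2 to compound 3 and a step that the two limits leave unreadable from compound 1 to compound 2. None of the three has a readable size, so none supplies a size to carry over. Going by the values given here, no compound carries a number yet, and no measured compound has a methoxy group. Across these three changes of the group, this assay has not left the limit, so no step beyond the scatter is expected here, in either direction. The most likely outcome is another limit, though a number close to it remains possible. The expected step is a number no higher from compound 3 to compound 4 (the limit leaves the size open). For compound 4 the estimate is 100000 nM, with an expected range of 40000 nM to 150000 nM.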

Compound 4, concentration for 50% growth inhibition: > 100000 nM
Compound 4 was reported as a limit; the forecaster's own chance of this, stated with the estimate: 80%; the middle value lies on the limit itself.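

In this assay compound 4 gives > 100000 nM as a limit and not a number. No step among compound 1, compound 2, compound 3 and compound 4 can be read, and all four stay together at the limit: the limit of > 100000 nM in this assay, at which 4 of the 4 values shown sit.

On these data alone, whether any group on the aromatic nitrogen of the shared core gives a readable value in this assay remains open.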